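This account rests on a few compounds, and the source may have more. Where it says the series, first, only, none or still open, it means among the compounds named here.

Compound 1, `Cc1ccc2c(NCc3ccc(NC(=O)C4CCN(Cc5ccc(Cl)cc5)CC4)cc3)nc(N(C)C)nc2c1`: > 3180 nM
Compound 2, `Cc1ccc2c(NCc3ccc(NC(=O)C4CCN(Cc5ccccc5)CC4)cc3)nc(N3CCNC(CCO)C3)nc2c1`: > 8420 nM
Compound 3, `Cc1ccc2c(NCc3ccc(NC(=O)C4CCN(CC5CCNCC5)CC4)cc3)nc(N(C)C)nc2c1`: > 8070 nM

All three measured compounds share one core and were tested in a functional assay on SV5A8 cells (Homo sapiens) for cytotoxicity; on this read-out higher numbers stand for weaker inhibition and lower numbers for stronger inhibition. None gave a number. For compound 1 the assay reported only a limit, > 3180 nM, as stated in the limit of > 3180 nM in this assay, at which 1 of the 3 values shown sits. For compound 3 the result is likewise a limit, > 8070 nM, as in the limit of > 8070 nM in this assay, at which 1 of the 3 values shown sits. Compound 2 also stands at a limit, > 8420 nM, as in the limit of > 8420 nM in this assay, at which 1 of the 3 values shown sits; it cannot be placed above or below the other two, since all three results are limits and no order among them can be read.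

Among the measured compounds shown here, the only pair that differs in one place is compound 1 and compound 3, where the change is a step that the two limits leave unreadable from compound 1 to compound 3. Both ends are limits, so the size of that step is unreadable.

Compound 4, `Cc1ccc2c(NCc3ccc(NC(=O)C4CCN(Cc5ccccc5)CC4)cc3)nc(N3CCN(C)CC3)nc2c1`, differs from compound 2 by 4-methylpiperazin-1-yl in place of 3-(2-hydroxyethyl)piperazin-1-yl on an aromatic carbon. For the measured compounds named here, this change sits on the core, at a place no measured step touches, and the one measured step gives no readable size. There is thus no ground to expect a step beyond the scatter in this assay in either direction; the most likely outcome is again a limit. Compound 4 is therefore estimated at 10000 nM, with a range from 3000 nM to 30000 nM. The expected step is a step that the limit leaves unreadable from compound 2 to compound 4.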

Compound 4, half-maximal inhibitory concentration: > 17700 nM
Compound 4 gave a limit, no number; the forecaster's own chance of this, stated with the estimate: 80%; middle value at least 1.7-fold (0.24 log units) away from the limit.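

Compound 2 and compound 4 both gave only limits, not numbers, so the step between them, from 3-(2-hydroxyethyl)piperazin-1-yl to 4-methylpiperazin-1-yl, cannot be read. The compounds shown leave open what concentration any of them truly needs for half-maximal inhibition in this assay and whether either single change shifts that concentration at all.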